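Enlarging the Saturated Ring on the Thiocarbonyl Amine

This account rests on a few compounds, and the source may have more. Where it says the series, first, only, none or still open, it means among the compounds named here.

Measured compounds in a functional assay on A-375 cells (Homo sapiens) for antiproliferative activity, read by CCK-8 assay, with a stated time of 72 h, tested at 8 uM; a lower number here means a weaker effect, a higher number a stronger effect of the compound at the concentration tested:
Compound 1, `Nc1ccccc1NC(=O)c1ccc(CSC(=S)N2CCN(Cc3ccccn3)CC2)cc1`: 82.4%
Compound 2, `Nc1ccccc1NC(=O)c1ccc(CSC(=S)N2CCc3ccccc32)cc1`: 85.4%
Compound 3, `Nc1ccccc1NC(=O)c1ccc(CSC(=S)N2CCN(c3cccnc3)CC2)cc1`: 88.8%

All three share the same core and differ only in the amine joined to the thiocarbonyl carbon. Compound 2 sits with the other two: its gap to compound 1 and its gap to compound 3 are both within the usual scatter, so no order among the three can be read from these numbers. Among the measured compounds shown here, the only step between two measured compounds that differ in one place is a number 6.4 percentage points higher from compound 1 to compound 3 (within the scatter); that change concerns a group on an amine nitrogen in a ring, not the amine on the thiocarbonyl carbon, and it also stays within the scatter.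

Compound 4, `Nc1ccccc1NC(=O)c1ccc(CSC(=S)N2CCCc3ccccc32)cc1`, has not been measured. 1,2,3,4-tetrahydroquinolin-1-yl in place of 2,3-dihydro-1H-indol-1-yl on a thiocarbonyl carbon The change keeps the six-membered aromatic ring of carbon only and the nitrogen on the thiocarbonyl carbon, and replaces the five-membered non-aromatic ring with a six-membered one. For the measured compounds named here, no measured step touches this place, and the three measured amines at the thiocarbonyl carbon all land close together, so nothing here points to a move beyond the scatter in either direction. Compound 4 is therefore expected to give 84% in this assay, within 72% to 92%. The expected step of a number 1.4 percentage points lower from compound 2 to compound 4 (within the scatter) lies within the scatter.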

Compound 4, a percentage reported as inhibition, at one concentration (the size of the read-out at that concentration, not a potency): 81.5%
Compound 4: middle estimate off by 2.5 percentage points, on the high side, and the stated range covers the measured number.
By their numbers in this assay, from the lowest: compounds 4, 1, 2 and 3 (each within the scatter of the next).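

In this assay, among the compounds shown here, this is the first measured step at the thiocarbonyl carbon itself: with 1,2,3,4-tetrahydroquinolin-1-yl in place of 2,3-dihydro-1H-indol-1-yl, the result is a number 3.9 percentage points lower from compound 2 to compound 4 (within the scatter). The five-membered non-aromatic ring can thus become a six-membered one without the read-out leaving the scatter, so this change shows no measurable effect at the one concentration tested, and the four compounds still cannot be separated. No measured information about these compounds bears on how the change acts on the cells.

The compounds shown leave open whether a quite different amine on the thiocarbonyl carbon, such as morpholine or open-chain diethylamine, would stay in the same range or fall clearly away from it. They also leave open whether compound 2 and compound 4 would differ in potency, since a percentage inhibition at a single concentration gives the size of the effect at that concentration and not the concentration needed to reach it.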